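A chlorophenyl replaces the cyclohexyl of compound 1

A few compounds are considered here, and "the series" means these few. Any claim that something is new, unique, unknown or untested is made for them only; others in the source may bear on it.

Compound 1 `O=C(Nc1ccc(Nc2nccc(NC3CCCCC3)n2)cc1)Nc1ccc(Cl)c(C(F)(F)F)c1` gives the lowest of the two numbers measured in a functional assay on MCF7 cells (Homo sapiens) for antiproliferative activity, read by MTT assay, with a stated time of 72 h (a lower number here means a stronger inhibitor, a higher number a weaker inhibitor), where compound 1 gives 10800 nM. Nearest to it is compound 3 `O=C(Nc1ccc(Nc2nccc(Nc3ccccc3Cl)n2)cc1)Nc1ccc(Cl)c(C(F)(F)F)c1`, for which this assay shows 27900 nM. Compound 2 `O=C(Nc1ccc(Nc2nccc(Nc3ccccc3)n2)cc1)Nc1ccc(Cl)c(C(F)(F)F)c1` reaches only the limit of this assay, where compound 2 shows > 50000 nM. Compound 4 `O=C(Nc1ccc(Nc2nccc(Nc3ccc(Cl)cc3)n2)cc1)Nc1ccc(Cl)c(C(F)(F)F)c1` has not yet been measured. It differs from compound 1 in one place: 4-chlorophenyl in place of cyclohexyl on a nitrogen on an aromatic ring. For the measured compounds named here, two measured steps bear on this change. Phenyl in place of cyclohexyl gave an at least 4.6-fold higher number from compound 1 to compound 2 (0.66 log units; beyond the scatter), a reading that sits at the limit of > 50000 nM in this assay, at which 1 of the 3 values shown sits. 2-chlorophenyl in place of cyclohexyl gave a 2.6-fold higher number from compound 1 to compound 3 (0.41 log units; beyond the scatter). Chloro in place of hydrogen on the phenyl gave an at least 1.7-fold lower number from compound 2 to compound 3 (0.25 log units; that floor lies within the scatter). Both aromatic replacements of the cyclohexyl weakened inhibition in this assay, and the 4-chlorophenyl is expected to do the same, so the step is estimated as a 3.2-fold higher number from compound 1 to compound 4 (0.51 log units; beyond the scatter). For compound 4 the expected value in this assay is 35000 nM, within a range from 12000 nM to 100000 nM, with a real chance that only the assay limit is reached.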

Compound 4, half-maximal inhibitory concentration: 12800 nM
The estimate for compound 4 lay 2.7-fold (0.44 log units) above the measured number; low and high end bracket the measured number.
By their numbers in this assay, from the lowest: compounds 1 and 4 (each within the scatter of the next); then compound 3. At a limit, above all of these: compound 2.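

In this assay, the 4-chlorophenyl on this nitrogen stands level with the cyclohexyl, with a 1.2-fold higher number from compound 1 to compound 4 (0.07 log units; within the scatter), so an aromatic ring in this place need not weaken inhibition, as compound 2 and compound 3 alone had suggested. The place of the chlorine on that ring also turns out to count, since 4-chlorophenyl in place of 2-chlorophenyl gives a 2.2-fold lower number from compound 3 to compound 4 (0.34 log units; beyond the scatter). From compound 2, whose reading is a limit and not a number, chloro in place of hydrogen on the phenyl gives an at least 3.9-fold lower number from compound 2 to compound 4 (0.59 log units; beyond the scatter), so this step is only a floor: the limit of > 50000 nM in this assay, at which 1 of the 4 values shown sits.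

A 4-fluorophenyl or 4-methoxyphenyl group on this nitrogen would show whether the level of compound 4 depends on chlorine itself or on any group at that place of the ring. Going by these compounds, it also remains open whether a cyclopentyl ring or an open alkyl chain on this nitrogen would give a lower number than the cyclohexyl and the 4-chlorophenyl do.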